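Changing the aryl group on the triazole nitrogen of a spirooxindole

The source may report more compounds than this note shows. Statements on the series, on what has been measured and on what is new or still open speak of the compounds shown alone.

Compound 2 `N#CC1=C(N)Oc2c(c3nc4ccccc4nc3c3ccccc23)C12C(=O)N(Cc1cnnn1-c1ccc(Br)cc1)c1ccccc12` shows only a limit in a functional assay on HCT-116 cells (Homo sapiens) for antiproliferative activity, read by MTT assay, with a stated time of 48 h (on this read-out higher numbers stand for weaker inhibition and lower numbers for stronger inhibition), giving > 50000 nM. Compound 1 `Cc1cccc(-n2nncc2CN2C(=O)C3(C(C#N)=C(N)Oc4c3c3nc5ccccc5nc3c3ccccc43)c3ccccc32)c1`, which differs by carrying 3-methylphenyl in place of 4-bromophenyl, likewise gives > 50000 nM as a limit, so a step that the two limits leave unreadable from compound 1 to compound 2 cannot be read, and the limit of > 50000 nM in this assay, at which 2 of the 2 values shown sit, tells that both values sit at the same limit. Compound 3 `CCOc1ccccc1-n1nncc1CN1C(=O)C2(C(C#N)=C(N)Oc3c2c2nc4ccccc4nc2c2ccccc32)c2ccccc21` differs from compound 2 by 2-ethoxyphenyl in place of 4-bromophenyl on an aromatic nitrogen. Among the measured compounds shown here, no measured step shows a readable size, so no shift beyond the scatter is expected in this assay, and a result again at the limit seems most likely. Compound 3 is estimated at 60000 nM, within 20000 nM to 200000 nM, which is expected as a step that the limit leaves unreadable from compound 2 to compound 3.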

Compound 3, half-maximal inhibitory concentration: > 50000 nM
Compound 3: only a limit was reported; the forecaster's own chance of this, stated with the estimate: 80%; the middle value does not contradict the limit.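

Compound 3 gives > 50000 nM in this assay and this is only a limit. Among the compounds shown here, no step among compound 1, compound 2 and compound 3 can be read: the limit of > 50000 nM in this assay, at which 3 of the 3 values shown sit. From the compounds shown here alone, how far the 3-methylphenyl, 4-bromophenyl and 2-ethoxyphenyl groups differ in activity stays open.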